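The source may hold more compounds than are shown below. What is called first, only, known or untested is meant among the compounds shown, and "the series" means these compounds.

Measured compounds:
compound 1 `COc1ccc(/C=C/c2cc(OC)cc(OC)c2/C=C/C(=O)Nc2cc(OC)c(OC)c(OC)c2)cc1` — 8150 nM
compound 2 `COc1ccc(/C=C/c2cc(OC)cc(OC)c2/C=C/C(=O)N2CCCCC2)cc1` — 9750 nM
compound 3 `CCCCN(CCCC)C(=O)/C=C/c1c(/C=C/c2ccc(OC)cc2)cc(OC)cc1OC` — 9030 nM

Three amides sharing one core have been tested in a functional assay on B16-F10 cells (Mus musculus) for inhibition, read by MTT assay, with a stated time of 48 h; a lower number here means a stronger inhibitor, a higher number a weaker inhibitor. Compound 1 gives 8150 nM, compound 2 gives 9750 nM and compound 3 gives 9030 nM. Compound 2 stands at the upper end of these three numbers, yet compound 3 and compound 1 both sit so close to it that no real separation can be read from the values.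

Compound 4 `CCCCCCNC(=O)/C=C/c1c(/C=C/c2ccc(OC)cc2)cc(OC)cc1OC` has not yet been measured in this assay. It differs from compound 2 in one place: hexylamino in place of piperidin-1-yl on a carbonyl carbon. Among the compounds with values here, the only measured step that bears on this change is the one in which a different amine replaces the same ring on the same carbonyl carbon: a 1.1-fold lower number from compound 2 to compound 3 (0.03 log units; within the scatter). That step stayed within the scatter, so the exchange of the piperidin-1-yl ring for an open-chain amine has so far left this assay unmoved.

For compound 4, an open-chain hexylamino group on the carbonyl carbon is therefore expected to give a step of about a 1.1-fold lower number from compound 2 to compound 4 (0.03 log units; within the scatter), no change beyond the scatter. The expected value for compound 4 is 9200 nM, with a range from 4500 nM to 19000 nM.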

Compound 4, half-maximal inhibitory concentration: 7180 nM
Compound 4: the middle estimate sits 1.3-fold (0.11 log units) above what was measured, within the range that was stated.
By their numbers in this assay, from the lowest: compounds 4, 1, 3 and 2 (each within the scatter of the next).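

In this assay, hexylamino on the carbonyl carbon brings one hydrogen-bond donor, the amide hydrogen, where piperidin-1-yl has none, and the step is a 1.4-fold lower number from compound 2 to compound 4 (0.13 log units; within the scatter). Set against the other two amides, the same compound gives a 1.3-fold lower number from compound 3 to compound 4 (0.10 log units; within the scatter) and, with hexyl in place of 3,4,5-trimethoxyphenyl on the amide-type nitrogen, a 1.1-fold lower number from compound 1 to compound 4 (0.06 log units; within the scatter). Across these four compounds, a single open chain on the nitrogen with its hydrogen kept can thus not be told apart from the ring, the dibutylamino group or the 3,4,5-trimethoxyphenyl group. As far as these compounds go, whether a morpholin-4-yl group or a longer chain on the same carbonyl carbon would move the number beyond the scatter stays open. Nothing available gives a reason for these small steps.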